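Chloro in place of hydrogen on a benzyl-linked purine core

This account rests on a few compounds, and the source may have more. Where it says the series, first, only, none or still open, it means among the compounds named here.

The set begins with compound 1 `ClCc1ccc(Cn2cnc3c(Cl)ncnc32)cc1`, which in a functional assay on BT-549 cells (Homo sapiens) for cytotoxicity, read by sulforhodamine B assay, with a stated time of 48 h (on this read-out lower numbers stand for stronger inhibition of growth and higher numbers for weaker inhibition of growth), gives 21400 nM. Compound 3 `ClCc1ccc(Cn2cnc3c(Cl)nc(Cl)nc32)cc1` carries the change chloro in place of hydrogen on an aromatic carbon relative to compound 1, and in this assay compound 3 gives 29500 nM; the resulting step of a 1.4-fold higher number from compound 1 to compound 3 (0.14 log units; within the scatter) is small. Compound 2 `ClCc1cccc(Cn2cnc3ncnc(Cl)c32)c1` shares its atoms with compound 1 but joins them differently, and the difference between the two cores is not broken down here; in this assay compound 2 gives 28800 nM. The values of compound 2 and compound 3 lie within the scatter of each other, as do those of compound 2 and compound 1.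

Compound 4 `ClCc1cccc(Cn2cnc3nc(Cl)nc(Cl)c32)c1` is not yet measured. It differs from compound 2 by chloro in place of hydrogen on an aromatic carbon, the same change that leads from compound 1 to compound 3, set at the same place. Because a 1.4-fold higher number from compound 1 to compound 3 (0.14 log units; within the scatter) was within the scatter, the step from compound 2 to compound 4 is expected to be similarly small, a 1.3-fold higher number from compound 2 to compound 4 (0.12 log units; within the scatter). Compound 4 is therefore estimated at 38000 nM, with a likely span from 20000 nM to 75000 nM.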

Compound 4, concentration for total growth inhibition: 1730 nM
The estimate for compound 4 lay 22-fold (1.34 log units) above the measured number; the whole stated range lies above it.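

In this assay, chloro in place of hydrogen on an aromatic carbon gives a 17-fold lower number from compound 2 to compound 4 (1.22 log units; beyond the scatter), whereas the same change on the core of compound 1 gives a 1.4-fold higher number from compound 1 to compound 3 (0.14 log units; within the scatter). The effect of this change therefore did not carry from one core to the other, and a step read on one core was a poor guide to the step on the other: the same change on two cores in this assay, a 1.4-fold higher number (0.14 log units; within the scatter) from compound 1 to compound 3 and a 17-fold lower number (1.22 log units; beyond the scatter) from compound 2 to compound 4, 23-fold (1.36 log units) apart, beyond the scatter of two such steps. Within the data shown here, this shows that the outcome of the change depends on the core that carries it, but with only two pairs it does not show which difference between the cores matters, nor how the change would behave on any further core.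

The compounds shown leave open whether an amine or a methoxy group on that same aromatic carbon, between two ring nitrogen atoms, would give a large step on the core of compound 2 and a small one on the core of compound 1. They also leave open whether the contrast between the two cores holds in any other cell line.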